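The compounds below may be only part of what the source reports. "The series", "measured", "known", "first", "only" and "open" are said of these compounds alone.

Measured in a functional assay on A549 cells (Homo sapiens) for antiproliferative activity, read by MTT assay, with a stated time of 48 h; on this read-out higher numbers stand for weaker inhibition of growth and lower numbers for stronger inhibition of growth:
- compound 1 `COC(=O)N1N=C(c2ccccc2)CC1c1cc(OC)c(OC)c(OC)c1`: 2880 nM
- compound 2 `COC(=O)N1N=C(c2ccccc2)CC1c1ccc(OC)cc1`: 15300 nM

Of these two numbers, compound 2 stands highest at 15300 nM. It therefore holds back growth less well than compound 1 at 2880 nM, and this gap lies beyond the usual scatter.

The next compound, compound 3 `COC(=O)N1N=C(c2ccccc2)CC1c1ccc(OC)c(OC)c1`, keeps the core of compound 2 and changes it in one place: methoxy in place of hydrogen on an aromatic carbon. The change is methoxy in place of hydrogen on an aromatic carbon.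

Going by the values given here, no measured pair isolates this change, so the expectation rests on only two compounds. Compound 1 carries further methoxy groups on the matching aromatic ring and reads 2880 nM, while compound 2 reads 15300 nM. In this assay, a modest move towards a lower number is therefore expected, landing between these two values, though it may not clear the scatter. The estimate is a 2.2-fold lower number from compound 2 to compound 3 (0.34 log units; beyond the scatter). For compound 3 the expected value is 7000 nM, with an estimated range from 2500 nM to 17000 nM.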

Compound 3, concentration for 50% growth inhibition: 7320 nM
Compound 3: middle estimate off by 1.0-fold (0.02 log units), on the low side, and the stated range covers the measured number.
By their numbers in this assay, from the lowest: compound 1; then compound 3; then compound 2.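

In this assay, adding one methoxy group to the ring of compound 2, ortho to a methoxy group and meta to a large group, gives a 2.1-fold lower number from compound 2 to compound 3 (0.32 log units; beyond the scatter) and so shows that this single change moves the number beyond the scatter on its own. The neighbouring change, hydrogen in place of methoxy, gives a 2.5-fold higher number from compound 1 to compound 3 (0.41 log units; beyond the scatter). These two modest steps, each beyond the scatter, show that the gap between compound 1 and compound 2 is not carried by one methoxy group alone. Nothing measured here speaks to the reason for either step.

On these data alone, whether the methoxy group itself matters at this place stays open, since a hydroxyl group, a fluorine atom or an ethoxy group in the same spot could give a similar or a different step. As far as these compounds go, it is also open whether the step would keep its size in a compound with a change elsewhere on the shared core, such as an amine on the second aromatic ring.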